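Rho kinase inhibitors: an aminomethylphenyl amide is examined

A few compounds are considered here, and "the series" means these few. Any claim that something is new, unique, unknown or untested is made for them only; others in the source may bear on it.

Of the compounds shown here, two built on the same core have been measured in an assay on isolated protein for inhibition of Rho-associated protein kinase 1 (Homo sapiens), read by scintillation counting, radiometric assay and 33P incorporation, with a stated time of 40 min, in the presence of a further agent that is not named here; a higher number here means a weaker inhibitor, a lower number a stronger inhibitor. Compound 1 `Cc1ccc(C(=O)Nc2cccc(NC(=O)COc3ccc4c(=O)ccoc4c3)c2)cc1` carries a 4-methylphenyl on the carbonyl carbon and gives 183 nM. Compound 2 `CC(C)(C)c1cc(C(=O)Nc2cccc(NC(=O)COc3ccc4c(=O)ccoc4c3)c2)no1` carries a 5-(tert-butyl)-1,2-oxazol-3-yl at that position and gives 101 nM. The step of a 1.8-fold lower number from compound 1 to compound 2 (0.26 log units; within the scatter) is the only measured one, and it lies within the scatter, so compound 2 and compound 1 cannot be told apart on these two numbers.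

Compound 3 `NCc1ccc(C(=O)Nc2cccc(NC(=O)COc3ccc4c(=O)ccoc4c3)c2)cc1` is not yet measured. It differs from compound 2 in one place: 4-(aminomethyl)phenyl in place of 5-(tert-butyl)-1,2-oxazol-3-yl on a carbonyl carbon. Within the data shown here, the single measured step changes the same position, and it shows that exchanging one group for another there moved the number only within the scatter. Among the measured compounds shown here, no step in the data addresses the aminomethyl group itself. On that basis the step from compound 2 to compound 3 is expected to be small, a 1.5-fold higher number from compound 2 to compound 3 (0.17 log units; within the scatter), in no direction that can be called beyond the scatter. The estimate for compound 3 in this assay is 150 nM, with a range from 40 nM to 600 nM.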

Compound 3, half-maximal inhibitory concentration: 532 nM
For compound 3 the middle estimate is 3.5-fold (0.55 log units) below the measured one; low and high end bracket the measured number.
By their numbers in this assay, from the lowest: compounds 2 and 1 (each within the scatter of the next); then compound 3.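

In this assay this position proves not to be indifferent to every exchange: the earlier pair stayed within the scatter, whereas a 5.3-fold higher number from compound 2 to compound 3 (0.72 log units; beyond the scatter) is a modest weakening beyond it. The comparison that isolates the change is the one that adds a single amino group to the saturated chain carbon of the 4-methylphenyl, leaving the rest of the molecule untouched, and it gives a 2.9-fold higher number from compound 1 to compound 3 (0.46 log units; beyond the scatter), so the loss also appears when the amino group is the only difference and not just when one ring replaces another. Nothing measured here explains why this amino group goes with weaker inhibition.

The compounds shown leave open whether a hydroxymethyl or a dimethylaminomethyl group in the same place would read like the 4-methylphenyl or like the 4-(aminomethyl)phenyl. They also leave open whether a longer chain, such as aminoethyl, would weaken inhibition further or recover it, and so whether the amine itself or its distance from the ring matters.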